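The compounds below may be only part of what the source reports. "The series", "measured", "known", "first", "only" and "open" are said of these compounds alone.

Of the compounds shown here, two have a number so far. Within the data shown here, compound 1 `CNC(=O)OC[C@H]1OC(n2cnc3c(NC4CCOC4)nc(Cl)nc32)[C@H](O)[C@@H]1O` and compound 2 `CCCCNC(=O)OC[C@H]1OC(n2cnc3c(NC4CCOC4)ncnc32)[C@H](O)[C@@H]1O` share the same core and both carry a carbamate on the sugar side chain; they also differ at a second point on the core, so no single step links them. In an assay on DDT1 cells (Cricetulus griseus) for binding affinity to adenosine receptor A1 (Homo sapiens), read by radioligand binding (on this read-out higher numbers stand for weaker inhibition and lower numbers for stronger inhibition), compound 1 gives 96 nM, and in this assay compound 2 gives 1410 nM. Compound 2 thus stands at the higher of the two numbers, the weaker end of what has been measured, and its gap to compound 1 is beyond the scatter.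

Compound 3 `O=C(NC1CCC1)OC[C@H]1OC(n2cnc3c(NC4CCOC4)ncnc32)[C@H](O)[C@@H]1O` has not been measured in this assay. It differs from compound 2 in one place: cyclobutyl in place of butyl on an amide-type nitrogen. Among the measured compounds shown here, no measured pair isolates this change, so the expectation rests on compound 2 alone. With the count of heavy atoms unchanged and no donor or acceptor added, the step is expected to be small, at most a modest move toward a lower number, and it may well stay within the scatter, so a 1.6-fold lower number from compound 2 to compound 3 (0.19 log units; within the scatter) is the estimated step. Compound 3 is accordingly expected to give about 900 nM in this assay, with a likely range from 300 nM to 2700 nM.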

Compound 3, inhibition constant: 306 nM
The estimate for compound 3 lay 2.9-fold (0.47 log units) above the measured number; low and high end bracket the measured number.
By their numbers in this assay, from the lowest: compound 1; then compound 3; then compound 2.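

In this assay, closing the butyl chain into cyclobutyl on the amide-type nitrogen gives a 4.6-fold lower number from compound 2 to compound 3 (0.66 log units; beyond the scatter), the first single-place step available in the series. This position therefore distinguishes two groups with equal heavy-atom counts and no hydrogen-bond donor or acceptor on either side, so the count of heavy atoms alone does not set the number here. No measurement at hand accounts for this step, and its origin remains unassigned.

From the compounds shown here alone, compound 1 differs from compound 2 and from compound 3 at two points, so the contributions of its methyl group and of the chloro substituent on the core cannot be separated, and whether the cyclobutyl step would carry over to a core bearing that chloro substituent remains open. Also open, going by these compounds, is whether the step belongs to the ring itself or would also appear with a branched group such as isopropyl or tert-butyl, and how the same nitrogen would respond to cyclopropyl, cyclopentyl, a longer chain or a chain ending in an amine.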